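This account rests on a few compounds, and the source may have more. Where it says the series, first, only, none or still open, it means among the compounds named here.

Measured so far:
compound 1 `c1ccc(COc2ccc(OCCOCCNC3CCCC3)cc2)cc1`: 24800 nM
compound 2 `COc1cc(OCCOCCNC2CCCC2)ccc1OCc1ccccc1`: 44600 nM
compound 3 `c1ccc(COc2ccc(OCCOCCNC3CC3)cc2)cc1`: 47200 nM

These three were tested in a functional assay on SK-OV-3 cells (Homo sapiens) for inhibition, read by CCK-8 assay, with a stated time of 70 h; a lower number here means a stronger inhibitor, a higher number a weaker inhibitor. Compound 1 gives the smallest number, yet the steps of a 1.8-fold higher number from compound 1 to compound 2 (0.25 log units; within the scatter) and a 1.9-fold higher number from compound 1 to compound 3 (0.28 log units; within the scatter) both lie within the scatter, so the three compounds cannot be told apart on these figures.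

Compound 4 `O=Cc1ccc(COc2ccc(OCCOCCNC3CCCC3)cc2)cc1` has not been measured. It differs from compound 1 in one place: formyl in place of hydrogen on an aromatic carbon. Neither measured step touches this part of the molecule: one changes a group on the central ring, the other the group on the amine nitrogen, and both stayed within the scatter. There is thus no direct guide, and with the change itself being small, no step beyond the scatter is expected in this assay. The expected step is a 1.0-fold higher number from compound 1 to compound 4 (0.00 log units; within the scatter). For compound 4 the estimate is 25000 nM, with a range from 10000 nM to 60000 nM.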

Compound 4, half-maximal inhibitory concentration: 45000 nM
For compound 4 the middle estimate is 1.8-fold (0.26 log units) below the measured one; the range from low to high includes it.
By their numbers in this assay, from the lowest: compounds 1, 2, 4 and 3 (each within the scatter of the next).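

In this assay, for the compounds shown here, replacing benzyl with 4-formylbenzyl brings a 1.8-fold higher number from compound 1 to compound 4 (0.26 log units; within the scatter) and so shows that this aromatic carbon, which the earlier steps left untouched, can carry a formyl group with no step that stands out from the scatter. Nothing measured here offers an explanation for this result.

On these data alone, whether an amine or a carboxylic acid on this same carbon would move the number beyond the scatter remains open. So does whether any change at this position can give a clearly stronger inhibitor.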